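Swapping the group on the sulfonyl sulfur of compound 3

The compounds below may be only part of what the source reports. "The series", "measured", "known", "first", "only" and "open" are said of these compounds alone.

In an ADME assay on microsomes from liver (Mus musculus) for metabolic stability, with a stated time of 10 min (on this read-out lower numbers stand for a less stable compound and higher numbers for a more stable compound), compound 1 `CS(=O)(=O)N1CCC(C(=O)N2CC[C@](c3ccc(C(F)(C(F)(F)F)C(F)(F)F)cc3)(S(=O)(=O)c3ccc(F)cc3)C2)CC1` gives 69% and compound 2 `O=C(O)C1CCN(C(=O)N2CC[C@](c3ccc(C(F)(C(F)(F)F)C(F)(F)F)cc3)(S(=O)(=O)c3ccc(F)cc3)C2)CC1` gives 88% remaining. Compound 3 `COc1ccc(S(=O)(=O)[C@@]2(c3ccc(C(F)(C(F)(F)F)C(F)(F)F)cc3)CCN(C(=O)[C@H]3CC[C@H](C(=O)O)CC3)C2)cc1` stands at 98% on this scale, which is within the scatter of compound 2 and far above compound 1.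

Compound 4 `O=C(O)[C@H]1CC[C@H](C(=O)N2CC[C@](c3ccc(C(F)(C(F)(F)F)C(F)(F)F)cc3)(S(=O)(=O)c3ccc(F)c(C4CC4)c3)C2)CC1` differs from compound 3 in one place, on a sulfonyl sulfur, where 3-cyclopropyl-4-fluorophenyl replaces 4-methoxyphenyl (3-cyclopropyl-4-fluorophenyl in place of 4-methoxyphenyl on a sulfonyl sulfur) and the rest of the molecule stays the same.

Among the measured compounds shown here, the only measured step that changes a single place is a number 19 percentage points higher from compound 1 to compound 2 (beyond the scatter) and it concerns a carbonyl carbon, where 4-carboxypiperidin-1-yl replaces 1-(methylsulfonyl)piperidin-4-yl. Compound 4 keeps the carbonyl side of compound 3, so this modest step says little here. For the measured compounds named here, no measured step shows what a swap on the sulfonyl sulfur does, and compound 2 and compound 3 differ in more than one place, so they cannot fill that gap.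

With compound 3 at 98% near the top of the scale, little room is left to rise, so no step beyond the scatter is expected, with a slight lean downward. The expected change is a number 8 percentage points lower from compound 3 to compound 4 (within the scatter) and it rests on thin evidence. For compound 4 the estimate is 90% with an expected range from 74% to 100% in repeat measurements.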

Compound 4, percent of the compound remaining: 74%
Beside the measured number, compound 4's estimate is 16 percentage points above it; the measured number falls inside the stated range.
By their numbers in this assay, from the lowest: compounds 1 and 4 (each within the scatter of the next); then compounds 2 and 3 (each within the scatter of the next).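

The sulfonyl sulfur turns out to be a sensitive position in this assay: with the rest of the molecule unchanged, putting 3-cyclopropyl-4-fluorophenyl in place of 4-methoxyphenyl gives a number 24 percentage points lower from compound 3 to compound 4 (beyond the scatter). This is the first single-place change shown at this sulfur, since the only earlier step of this kind concerned a carbonyl carbon, and it shows that keeping the carbonyl side of compound 3 does not by itself hold a compound near the top of the scale. Nothing shown gives a measured reason for this drop.

The swap removes a methoxy group and adds both a cyclopropyl ring and a fluorine in one move, so the compounds shown cannot tell which of these changes carries the step. As far as these compounds go, a plain phenyl ring on the sulfonyl sulfur, or an isopropyl group in place of the cyclopropyl ring, would help pull these parts apart, and it also remains open whether the same swap would have a similar size with a different group on the carbonyl side.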